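The compounds below may be only part of what the source reports. "The series", "measured", "known", "first", "only" and "open" are said of these compounds alone.

Measured so far in a functional assay on Shh Light II cells (Mus musculus) for inhibition, read by a luciferase reporter; a lower number here means a stronger inhibitor, a higher number a weaker inhibitor:
- compound 1 (`C[C@@H]1C[C@H](c2nc(-c3ccc4ccccc4n3)no2)CCN1C(=O)Nc1ccccc1Cl`) 2400 nM
- compound 2 (`O=C(CC1CCCCCC1)N1CCC(c2nc(-c3ccc4ccccc4n3)no2)CC1`) 840 nM

Compound 2, at 840 nM, has the lower number of the two, and its gap to compound 1 lies beyond the scatter. Compound 3 (`O=C(NC1CCC(O)CC1)N1CCC(c2nc(-c3ccc4ccccc4n3)no2)CC1`) remains unmeasured. It differs from compound 2 by (4-hydroxycyclohexyl)amino in place of cycloheptylmethyl on a carbonyl carbon, with (4-hydroxycyclohexyl)amino in place of cycloheptylmethyl on a carbonyl carbon. Within the data shown here, no measured pair covers this change, so the expectation is tentative. The expected change is a 3.6-fold higher number from compound 2 to compound 3 (0.55 log units; beyond the scatter) in this assay, towards weaker inhibition and beyond the scatter. For compound 3 the estimate is 3000 nM, with an expected range from 800 nM to 10000 nM for the measurement.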

Compound 3, half-maximal inhibitory concentration: 2700 nM
Beside the measured number, compound 3's estimate is 1.1-fold (0.05 log units) above it; measured number inside the range.
By their numbers in this assay, from the lowest: compound 2; then compounds 1 and 3 (each within the scatter of the next).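

On the carbonyl carbon whose other neighbour is the amide-type nitrogen in a ring, (4-hydroxycyclohexyl)amino in place of cycloheptylmethyl gives a 3.2-fold higher number from compound 2 to compound 3 (0.51 log units; beyond the scatter) in this assay, so this position does respond to substitution. The change is a combined one, altering the ring from seven-membered to six-membered and adding the amino link and the hydroxyl in a single step. No supporting data explain this step. Which of these parts carries the step remains open. A cyclohexylamino group without the hydroxyl, or a cycloheptylamino group, on the same carbonyl carbon would separate them.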